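Ethoxycarbonyl in Place of Methyl on the Ring Nitrogen

This account rests on a few compounds, and the source may have more. Where it says the series, first, only, none or still open, it means among the compounds named here.

Compound 2 `CN1CC2(CC(=O)c3cc(/C=C/C(=O)NO)ccc3O2)C1` stands lowest of the three measured numbers in a functional assay on A549 cells (Homo sapiens) for antiproliferative activity, read by luminescence, with a stated time of 72 h (a lower number here means a stronger inhibitor, a higher number a weaker inhibitor), with 429 nM. Compound 1 `O=C(/C=C/c1ccc2c(c1)C(=O)CC1(CNC1)O2)NO` gives 8580 nM in this assay, and compound 3 `CC(=O)N1CC2(CC(=O)c3cc(/C=C/C(=O)NO)ccc3O2)C1` gives 47700 nM. Compound 4 `CCOC(=O)N1CC2(CC(=O)c3cc(/C=C/C(=O)NO)ccc3O2)C1` differs from compound 2 by ethoxycarbonyl in place of methyl on an amine nitrogen in a ring. For the measured compounds named here, two measured steps bear on this change: a 110-fold higher number from compound 2 to compound 3 (2.05 log units; beyond the scatter), and a 5.6-fold higher number from compound 1 to compound 3 (0.75 log units; beyond the scatter); by contrast, a 20-fold lower number from compound 1 to compound 2 (1.30 log units; beyond the scatter). Since acetyl on this nitrogen raised the number sharply, the step is expected to be large in the same direction, namely a 58-fold higher number from compound 2 to compound 4 (1.77 log units; beyond the scatter). Compound 4 is accordingly estimated at 25000 nM in this assay, within a range from 6000 nM to 80000 nM.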

Compound 4, half-maximal inhibitory concentration: 4870 nM
Compound 4: middle estimate off by 5.1-fold (0.71 log units), on the high side; measured number below the stated range.
By their numbers in this assay, from the lowest: compound 2; then compounds 4 and 1 (each within the scatter of the next); then compound 3.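

In this assay, a carbonyl on this ring nitrogen does not settle the outcome by itself: ethoxy in place of methyl on the carbonyl carbon gives a 9.8-fold lower number from compound 3 to compound 4 (0.99 log units; beyond the scatter). Ethoxycarbonyl still compares poorly with methyl, at an 11-fold higher number from compound 2 to compound 4 (1.06 log units; beyond the scatter), while against hydrogen on the nitrogen it gives a 1.8-fold lower number from compound 1 to compound 4 (0.25 log units; within the scatter), so compound 4 and compound 1 cannot be told apart. Nothing available accounts for these differences. As far as these compounds go, whether an ethyl group on this nitrogen would match methyl, or a tert-butoxycarbonyl group would match ethoxycarbonyl, remains open.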